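The source may report more compounds than this note shows. Statements on the series, on what has been measured and on what is new or still open speak of the compounds shown alone.

Three compounds have so far been measured in a functional assay on HepG2 cells (Homo sapiens) for cytotoxicity, read by MTT assay, with a stated time of 48 h; a higher number here means a weaker inhibitor, a lower number a stronger inhibitor:

Compound 1, `COc1cc(-c2nnc3n2NC(c2cccs2)C(C(=O)c2ccc(C)cc2)S3)cc(OC)c1OC`: 3700 nM
Compound 2, `COc1cc(-c2nnc3n2NC(c2ccco2)C(C(=O)c2ccc(C)cc2)S3)cc(OC)c1OC`: 17400 nM
Compound 3, `COc1cc(-c2nnc3n2NC(c2cccs2)C(C(=O)c2ccc(Cl)cc2)S3)cc(OC)c1OC`: 13200 nM

Compound 2 stands highest of these three numbers. Compound 3 lies within the scatter of it, while compound 1 lies clearly apart: a 4.7-fold higher number from compound 1 to compound 2 (0.67 log units; beyond the scatter). Compound 4, `COc1cc(-c2nnc3n2NC(c2ccco2)C(C(=O)c2ccco2)S3)cc(OC)c1OC`, differs from compound 2 in one place: furan-2-yl in place of 4-methylphenyl on a carbonyl carbon.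

Within the data shown here, no measured step touches the group on this carbonyl carbon directly. The step of a 3.6-fold higher number from compound 1 to compound 3 (0.55 log units; beyond the scatter) alters the 4-methylphenyl at one aromatic carbon but keeps the ring itself. The step of a 4.7-fold higher number from compound 1 to compound 2 (0.67 log units; beyond the scatter) does bring in a furan-2-yl, yet on a saturated ring carbon, not on the carbonyl. Neither step therefore bears squarely on the change to compound 4; both, however, were modest rises. On that thin basis the step is expected to be small, with a slight lean toward a higher number, a 1.3-fold higher number from compound 2 to compound 4 (0.10 log units; within the scatter). Compound 4 is estimated at 22000 nM, with a range from 7000 nM to 70000 nM.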

Compound 4, half-maximal inhibitory concentration: > 100000 nM
Compound 4 was reported as a limit; the forecaster's own chance of this, stated with the estimate: 10%; middle value at least 4.5-fold (0.65 log units) away from the limit.
By their numbers in this assay, from the lowest: compound 1; then compounds 3 and 2 (each within the scatter of the next). At a limit, above all of these: compound 4.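

Swapping 4-methylphenyl for furan-2-yl on the carbonyl carbon, a place no earlier step touched, gives an at least 5.7-fold higher number from compound 2 to compound 4 (0.75 log units; beyond the scatter), which shows that the number is sensitive to the group held at this carbonyl carbon. Compound 4 was reported only as a limit: the limit of > 100000 nM in this assay, at which 1 of the 4 values shown sits. Among these compounds, the true number of compound 4 and the full size of this step therefore stay unknown, and the step shows only that this one change takes the compound out of the measurable range.

The compounds shown leave open whether the same change would have a like effect with thiophen-2-yl on the saturated ring carbon, since compound 4 carries furan-2-yl there. They also leave open how an unsubstituted phenyl, a pyridine ring or a cyclohexyl group would read on this carbonyl carbon.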